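Swapping One Halogen: From Compound 3 to Compound 4

The source may report more compounds than this note shows. Statements on the series, on what has been measured and on what is new or still open speak of the compounds shown alone.

- compound 1 `C#Cc1cccc(Nc2ncnc3cc(NC(=O)/C=C/c4ccccc4)sc23)c1`: 26200 nM
- compound 2 `N#Cc1cccc(Nc2ncnc3cc(NC(=O)/C=C/c4ccccc4)sc23)c1`: 17200 nM
- compound 3 `O=C(/C=C/c1ccccc1)Nc1cc2ncnc(Nc3ccc(F)c(Cl)c3)c2s1`: 6670 nM

In a functional assay on A549 cells (Homo sapiens) for antiproliferative activity, read by MTT assay, with a stated time of 48 h (a lower number here means a stronger inhibitor, a higher number a weaker inhibitor), compound 3 gives 6670 nM, the lowest of the three numbers, which makes it the strongest inhibitor measured so far. Compound 4 `O=C(/C=C/c1ccccc1)Nc1cc2ncnc(Nc3ccc(Cl)c(Cl)c3)c2s1` differs from it in a single atom: chloro in place of fluoro on an aromatic carbon. The 3-chloro-4-fluorophenyl group thus becomes 3,4-dichlorophenyl.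

Going by the values given here, no measured pair makes this exact swap. The closest evidence comes from replacing the whole group on the nitrogen. That gave a 3.9-fold lower number from compound 1 to compound 3 (0.59 log units; beyond the scatter) and a 2.6-fold lower number from compound 2 to compound 3 (0.41 log units; beyond the scatter), both modest, while the swap of ethynyl for cyano gave a 1.5-fold lower number from compound 1 to compound 2 (0.18 log units; within the scatter). Even these larger structural changes moved the number only a little, so a single halogen exchange is expected to produce no step beyond the scatter in this assay, and no direction can be favoured. The expected change is a 1.1-fold lower number from compound 3 to compound 4 (0.05 log units; within the scatter). For compound 4 the estimated value is 6000 nM, with an expected range of 2500 nM to 14000 nM.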

Compound 4, half-maximal inhibitory concentration: 19500 nM
Compound 4: the middle estimate sits 3.3-fold (0.51 log units) below what was measured, and the stated range ends below it.
By their numbers in this assay, from the lowest: compound 3; then compounds 2, 4 and 1 (each within the scatter of the next).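

In this assay, changing a single atom on the aromatic ring, para to a large group, gives a 2.9-fold higher number from compound 3 to compound 4 (0.47 log units; beyond the scatter) and so matters about as much as replacing the whole group on the nitrogen, which gave a 2.6-fold lower number from compound 2 to compound 3 (0.41 log units; beyond the scatter) in the earlier series. With chloro in place of fluoro, the edge of compound 3 disappears: the comparisons give a 1.1-fold higher number from compound 2 to compound 4 (0.05 log units; within the scatter) and a 1.3-fold lower number from compound 1 to compound 4 (0.13 log units; within the scatter) and leave compound 4 level with both of the other compounds. Nothing in the available data explains why this one exchange has such an effect.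

From the compounds shown here alone, what hydrogen, bromo, methyl or methoxy would do at this same place remains open. Going by these compounds, it is also open whether the exchange of fluoro for chloro would give a step of similar size in other cell lines.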